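This account rests on a few compounds, and the source may have more. Where it says the series, first, only, none or still open, it means among the compounds named here.

In an ADME assay on microsomes from liver (Mus musculus) for metabolic stability, with a stated time of 10 min (a lower number here means that less of the compound is left, a higher number that more of the compound is left), compound 1 (`CC(=O)N1CCN(C(=O)N2CC[C@](c3ccc(C(OCc4c(F)cccc4C#N)(C(F)(F)F)C(F)(F)F)cc3)(S(=O)(=O)c3ccc(F)cc3)C2)CC1`) gives 1% and stands apart from the other two compounds, lower by a margin well beyond the scatter. Compound 2 (`O=C(O)C1CCN(C(=O)N2CC[C@](c3ccc(C(OCc4c(F)cccc4F)(C(F)(F)F)C(F)(F)F)cc3)(S(=O)(=O)c3ccc(F)cc3)C2)CC1`) gives 84% and compound 3 (`Cc1cccc(C)c1COC(c1ccc([C@]2(S(=O)(=O)c3ccc(F)cc3)CCN(C(=O)[C@H]3CC[C@H](C(=O)O)CC3)C2)cc1)(C(F)(F)F)C(F)(F)F`) gives 77% with no gap beyond the scatter between these two. Among the compounds with values here, compound 3 therefore stands with compound 2, at the upper end of the numbers so far. Compound 4 (`COc1cccc(F)c1COC(c1ccc([C@]2(S(=O)(=O)c3ccc(F)cc3)CCN(C(=O)[C@H]3CC[C@H](C(=O)O)CC3)C2)cc1)(C(F)(F)F)C(F)(F)F`) departs from compound 3 by a single change (2-fluoro-6-methoxyphenyl in place of 2,6-dimethylphenyl on a saturated chain carbon bound to an oxygen on a saturated carbon) of 2-fluoro-6-methoxyphenyl in place of 2,6-dimethylphenyl on a saturated chain carbon bound to an oxygen on a saturated carbon. Within the data shown here, no two measured compounds differ in one place only, so this change has no direct precedent here. Compound 2, which has a different group at this place and differs elsewhere too, still gives 84% and so a large move is not expected. The estimated step (a number 7 percentage points lower from compound 3 to compound 4 (within the scatter)) is a small fall, within the scatter. For compound 4 the expected value is 70% (estimated range 45% to 88%).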

Compound 4, percent of the compound remaining: 88%
Compound 4: middle estimate off by 18 percentage points, on the low side; the measured number falls inside the stated range.
By their numbers in this assay, from the lowest: compound 1; then compounds 3, 2 and 4 (each within the scatter of the next, the first and the last beyond it).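

In this assay, within the data shown here, placing 2-fluoro-6-methoxyphenyl in place of 2,6-dimethylphenyl on a saturated chain carbon bound to an oxygen on a saturated carbon gives a number 11 percentage points higher from compound 3 to compound 4 (beyond the scatter) as the first change here that can be read in one place. Among these compounds, it shows that the number responds to the substituents on this aromatic ring, and that the methoxy and fluoro pair keeps the compound at the upper end of the numbers so far. Nothing at hand explains the rise. As far as these compounds go, both substituents change together in this step, so the share of each remains open. Also open, from the compounds shown here alone, is how an ethoxy group or a dimethylamino group in place of the methoxy would read at this place.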